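The source may hold more compounds than are shown below. What is called first, only, known or untested is meant among the compounds shown, and "the series" means these compounds.

compound 1 `COc1ccccc1OCC1SCCN1C(=O)CC(C)=O` gives 30 mg/kg
compound 2 `CCOC(=O)C(C)(C)C(=O)N1CCSC1COc1ccccc1OC` gives 61 mg/kg
compound 3 `COc1ccccc1OCC1SCCN1C(=O)CC(=O)N1CCN(C)CC1` has no value yet

In a functional assay on the whole organism for inhibition, with Cavia porcellus as the target (on this read-out higher numbers stand for an effect only at larger amounts of compound and lower numbers for an effect already at smaller amounts), compound 1 gives 30 mg/kg as the lower of the two numbers. Compound 3 differs from compound 1 by 4-methylpiperazin-1-yl in place of methyl on a carbonyl carbon on a carbonyl carbon. Among the compounds with values here, only one measured step bears on this change: a 2.0-fold higher number from compound 1 to compound 2 (0.31 log units; beyond the scatter) with a different entering group. From that single step to compound 2, a similarly modest rise in this assay is expected, though one step fixes the direction only weakly. The expected step is a 1.4-fold higher number from compound 1 to compound 3 (0.15 log units; within the scatter) as estimated here. Compound 3 is estimated at 42 mg/kg with an expected range of 14 mg/kg to 125 mg/kg on this reading.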

Compound 3, dose for half-maximal effect: 27 mg/kg
Compound 3: middle estimate off by 1.6-fold (0.19 log units), on the high side; measured number inside the range.
By their numbers in this assay, from the lowest: compounds 3 and 1 (each within the scatter of the next); then compound 2.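

In this assay, 4-methylpiperazin-1-yl in place of methyl on a carbonyl carbon gives a 1.1-fold lower number from compound 1 to compound 3 (0.05 log units; within the scatter), so the ring of the entering group leaves the number within the scatter. The earlier change to 1-(ethoxycarbonyl)-1-methylethyl, which gave a 2.0-fold higher number from compound 1 to compound 2 (0.31 log units; beyond the scatter), therefore does not show that every added bulk at this part of compound 1 raises the number. Nothing available on these compounds accounts for this result.

Still open, on these data alone, is how a carboxylic acid, a primary amine or a longer chain between the carbonyl carbon and the piperazine would read out. Morpholin-4-yl in place of 4-methylpiperazin-1-yl is equally open.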